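Clearance series: a ring isomer of compound 3

The source may report more compounds than this note shows. Statements on the series, on what has been measured and on what is new or still open speak of the compounds shown alone.

Three compounds share one core and have been run in an ADME assay on the whole organism (Rattus norvegicus) for pharmacokinetics, at a dose of 1 mg/kg by the intravenous route; on this read-out lower numbers stand for slow clearance and higher numbers for fast clearance. Compound 1 `Cc1nnc(N2CCC(C(=O)N3N=CC[C@H]3c3cc(F)cc(F)c3)CC2)o1` gives 14 mL/min/kg. Compound 2 `O=C(c1cnco1)N1CCC(C(=O)N2N=CC[C@H]2c2ccccc2)CC1` gives 42 mL/min/kg. Compound 3 `N#Cc1cc(N2CCC(C(=O)N3N=CC[C@H]3c3cc(F)cc(F)c3)CC2)ncn1` gives 46 mL/min/kg, the highest of the three numbers, though the values of compound 3 and compound 2 lie within the usual scatter of each other and only compound 1 sits clearly apart.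

One step is measured: a 3.3-fold higher number from compound 1 to compound 3 (0.52 log units; beyond the scatter), for a group of 8 heavy atoms (5 carbon, 3 nitrogen; one six-membered aromatic ring with 2 hetero atoms) in place of a group of 6 heavy atoms (3 carbon, 2 nitrogen, 1 oxygen; one five-membered aromatic ring with 3 hetero atoms), on an amine nitrogen in a ring.

Compound 4 `N#Cc1cnc(N2CCC(C(=O)N3N=CC[C@H]3c3cc(F)cc(F)c3)CC2)cn1` differs from compound 3 by a group of 8 heavy atoms (5 carbon, 3 nitrogen; one six-membered aromatic ring with 2 hetero atoms) in place of a group of 8 heavy atoms (5 carbon, 3 nitrogen; one six-membered aromatic ring with 2 hetero atoms), on an amine nitrogen in a ring. Among the measured compounds shown here, the two have the same atoms, joined differently, so the only measured step does not speak to this change: it replaces a five-membered ring by a six-membered one, whereas here one six-membered aromatic ring with 2 hetero atoms gives way to another. For the measured compounds named here, no measured pair isolates such an isomer swap.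

The step of a 1.1-fold lower number from compound 3 to compound 4 (0.04 log units; within the scatter) is therefore expected to stay within the scatter. Compound 4 is estimated at 42 mL/min/kg, with a range from 22 mL/min/kg to 80 mL/min/kg in this assay .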

Compound 4, clearance: 47 mL/min/kg
Compound 4: middle estimate off by 1.1-fold (0.05 log units), on the low side; the range from low to high includes it.
By their numbers in this assay, from the lowest: compound 1; then compounds 2, 3 and 4 (each within the scatter of the next).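

Within this assay, the change to 5-cyanopyrazin-2-yl on the amine nitrogen in a ring gives a 1.0-fold higher number from compound 3 to compound 4 (0.01 log units; within the scatter), the first measured pair at this position in which one six-membered aromatic ring with 2 hetero atoms replaces an isomer of itself, and these two isomers are not told apart on this read-out. Replacing 5-methyl-1,3,4-oxadiazol-2-yl with 5-cyanopyrazin-2-yl gives a 3.4-fold higher number from compound 1 to compound 4 (0.53 log units; beyond the scatter), and alongside a 3.3-fold higher number from compound 1 to compound 3 (0.52 log units; beyond the scatter) this shows that the separation from compound 1 holds for both six-membered groups, not just one. No measurement bears on the origin of these numbers.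

The compounds shown leave open whether the separation of compound 1 at 14 mL/min/kg goes with the five-membered ring itself, with its methyl group, or with the nitrile carried by the six-membered groups, since ring and substituent change together in both steps. A methoxy group or an amide in place of the nitrile on the pyrazine, with the shared core kept, would separate these readings.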